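Swapping an Aminophenyl for a Dichlorophenyl on the Core

The compounds below may be only part of what the source reports. "The series", "measured", "known", "first", "only" and "open" are said of these compounds alone.

Of the compounds shown here, two that share a core have so far been measured in a functional assay on HCT-116 cells (Homo sapiens) for inhibition, read by sulforhodamine B assay, with a stated time of 48 h; a lower number here means a stronger inhibitor of growth, a higher number a weaker inhibitor of growth. Compound 1 `COc1cc(-c2cc(/C=C/C(=O)c3ccc(N)cc3)[nH]n2)cc(OC)c1OC` gives 2610 nM in this assay, the highest number of the two. Compound 2 `COc1ccc(-c2cc(/C=C/C(=O)c3ccc(OC)c(OC)c3)[nH]n2)cc1` gives 2480 nM in this assay, and the two values lie within the usual scatter of one another, so nothing separates them. Among the compounds with values here, compound 2 differs from compound 1 in more than one place, so no single step between them can be read.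

Compound 3 `COc1cc(-c2cc(/C=C/C(=O)c3ccc(Cl)c(Cl)c3)[nH]n2)cc(OC)c1OC` has not yet been measured in this assay. It differs from compound 1 in one place: 3,4-dichlorophenyl in place of 4-aminophenyl on a carbonyl carbon. Within the data shown here, no measured pair shows what this change does. With nothing to set a direction, the expected step of a 1.0-fold lower number from compound 1 to compound 3 (0.02 log units; within the scatter) in this assay is none beyond the scatter. Compound 3 is therefore expected to give about 2500 nM in this assay, within a range from 800 nM to 8000 nM.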

Compound 3, concentration for total growth inhibition: 21500 nM
The estimate for compound 3 lay 8.6-fold (0.93 log units) below the measured number; measured number above the stated range.
By their numbers in this assay, from the lowest: compounds 2 and 1 (each within the scatter of the next); then compound 3.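

At the carbonyl carbon, the group is not interchangeable: in this assay, placing 3,4-dichlorophenyl where compound 1 has 4-aminophenyl gives an 8.2-fold higher number from compound 1 to compound 3 (0.92 log units; beyond the scatter) and so weakens growth inhibition. This single step changes several things at once, replacing a group that has a hydrogen-bond donor and acceptor with one that has neither and adding two chlorine atoms, so it cannot show which of these differences matters. Nothing available here accounts for the weaker inhibition.

The compounds shown leave open whether an unsubstituted phenyl or a phenyl carrying a single chlorine at the carbonyl carbon would stay close to compound 1 or fall toward compound 3. They also leave open whether a hydroxyl or methoxy group on that ring could stand in for the amine.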